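The compounds below may be only part of what the source reports. "The series", "measured", "known", "first", "only" and "open" are said of these compounds alone.

Compound 1 `C[Se]c1ccc(N(C)c2nc(C3CC3)nc3ccccc23)cc1` gives 18 nM.
Compound 2 `C[Se]c1ccc(N(C)c2nc(C)nc3ccccc23)cc1C` gives 7 nM.
Compound 3 `COc1ccc(N(C)c2nc(C)nc3ccccc23)cc1OCCCCC[Se]C#N` gives 4410 nM.

All three were tested in a functional assay on MDA-MB-231 cells (Homo sapiens) for inhibition, read by MTT assay, with a stated time of 48 h; on this read-out higher numbers stand for weaker inhibition and lower numbers for stronger inhibition. Compound 3 stands apart from the other two: its number is the highest of the three, and the gap to compound 1, the nearest of them, is far beyond the usual scatter of repeated measurements, while the gap to compound 2 is wider still. Compound 3 carries a long chain on one of the oxygens of its shared core, ending in a selenium-bearing group, whereas compound 1 and compound 2 carry a much smaller selenium group directly on their ring.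

Compound 4 `COc1ccc(N(C)c2nc(C)nc3ccccc23)cc1OCCCC[Se]C#N` is the next compound. It differs from compound 3 only in the length of that chain: a group of 3 heavy atoms (1 carbon, 1 nitrogen, 1 selenium; no ring) in place of a group of 4 heavy atoms (2 carbon, 1 nitrogen, 1 selenium; no ring), on a saturated chain carbon, four bonds along the chain from an oxygen on an aromatic ring. The end group and the ring system stay the same, so the change is a single link shortened in a flexible chain. Within the data shown here, no pair of measured compounds shows what such a shortening does here. With the selenium group kept and the chain only slightly shorter, the step in this assay is expected to stay within the scatter, with no clear direction. Compound 4 is therefore estimated to give 4000 nM, within a range from 1500 nM to 11000 nM, which means an expected step of a 1.1-fold lower number from compound 3 to compound 4 (0.04 log units; within the scatter).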

Compound 4, half-maximal inhibitory concentration: 1350 nM
Estimate against measurement, compound 4: 3.0-fold (0.47 log units) above, and the stated range ends above it.
By their numbers in this assay, from the lowest: compound 2; then compound 1; then compound 4; then compound 3.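

Removing a single link from the flexible chain, on a saturated chain carbon, four bonds along the chain from an oxygen on an aromatic ring, gives a 3.3-fold lower number from compound 3 to compound 4 (0.51 log units; beyond the scatter) in this assay. Among these compounds, this is the first one-place comparison in the set, and it shows that chain length at this position can change the read-out beyond the usual scatter, even though the end group and the shared core stay the same. The change is modest and points towards stronger inhibition with the shorter chain, but nothing measured here explains it.

A single step between two chain lengths cannot show whether the number would keep falling with a still shorter chain, rise again with a longer chain, or follow no steady trend. From the compounds shown here alone, it also remains open how much the end of the chain contributes in its own right, for instance whether sulfur in place of the selenium, or a methyl group in place of the nitrile, would keep the number where it stands.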